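Amide aryl exchange in compound 1

The source may hold more compounds than are shown below. What is called first, only, known or untested is meant among the compounds shown, and "the series" means these compounds.

Three compounds have values in a functional assay on HEK293 cells for agonist activity at D(4) dopamine receptor (Homo sapiens), read by FLIPR; a higher number here means a larger maximal response, a lower number a smaller maximal response. Compound 1 `Cc1cc(C(=O)NCN2CCC(c3cccc[n+]3[O-])CC2)ccc1F` gives 67%; compound 2 `Cc1cccc(NC(=O)CN2CCC(c3ccccc3)CC2)c1` gives 37%; compound 3 `Oc1ccc(N2CCN(Cc3nc4ccccc4[nH]3)CC2)nc1` gives 70%. Compound 1 stands second highest of the three. Its nearest neighbour is compound 3, whose value lies within the usual scatter of that of compound 1, so no order between these two can be read. Compound 2 lies furthest away, with a value well beyond the scatter below compound 1. Among the compounds with values here, no pair of the measured compounds differs at a single place, so no step along the series has been measured.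

Compound 4 `O=C(NCN1CCC(c2cccc[n+]2[O-])CC1)c1ccccn1` is the next compound. It differs from compound 1 in one place: pyridin-2-yl in place of 4-fluoro-3-methylphenyl on a carbonyl carbon. The 4-fluoro-3-methylphenyl group leaves and a pyridin-2-yl group enters, with the rest of compound 1 kept. Nothing measured in the series tells how this assay responds to such an exchange on the carbonyl carbon. The reading of compound 1, 67%, is the only anchor. The expectation is a small move, if any, not beyond the scatter and tending slightly downward, a number 7 percentage points lower from compound 1 to compound 4 (within the scatter). Compound 4 is expected to give 60%, within 40% to 80%.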

Compound 4, largest response reached (reported as efficacy), in percent of the reference or control that the assay uses: 40%
The estimate for compound 4 lay 20 percentage points above the measured number, within the range that was stated.
By their numbers in this assay, from the lowest: compounds 2 and 4 (each within the scatter of the next); then compounds 1 and 3 (each within the scatter of the next).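

Within the data shown here, the aryl group on the carbonyl carbon is the first place where a single exchange can be read, and this assay responds to it: pyridin-2-yl in place of 4-fluoro-3-methylphenyl gives a number 27 percentage points lower from compound 1 to compound 4 (beyond the scatter). The maximal response therefore depends on this group, even with the rest of compound 1 kept. No measured property of either group bears on this step, and its origin stays unexplained.

The exchange brings in a ring nitrogen and removes the fluorine and the methyl group in one step, and the compounds shown do not separate these parts. Going by these compounds, it remains open whether a plain phenyl or a thienyl group on the carbonyl carbon would give a response closer to that of compound 1 or to that of compound 4.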